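From methyl to 2-hydroxyethyl on an aromatic nitrogen

This account rests on a few compounds, and the source may have more. Where it says the series, first, only, none or still open, it means among the compounds named here.

Compound 1 `CNC(=O)Nc1ccc(-c2nc(N3CC4CCC(C3)O4)c3cnn(C)c3n2)cc1` gives 170 nM
Compound 2 `O=C(Nc1ccccc1)Nc1ccc(-c2nc(N3CC4CCC(C3)O4)c3cnn(C4CCC5(CC4)OCCO5)c3n2)cc1` gives 4 nM
Compound 3 `O=C(Nc1ccc(-c2nc(N3CC4CCC(C3)O4)c3cnn(C4CCC5(CC4)OCCO5)c3n2)cc1)Nc1cccnc1` gives 1 nM
Compound 4 `CNC(=O)Nc1ccc(-c2nc(N3CC4CCC(C3)O4)c3cnn(CCO)c3n2)cc1` has not yet been measured

In a functional assay on LNCaP cells (Homo sapiens) for cytotoxicity (on this read-out lower numbers stand for stronger inhibition and higher numbers for weaker inhibition), compound 1 has the highest number of the three, and both compound 2 and compound 3 lie well under it. Compound 4 differs from compound 1 in one place (hydroxymethyl in place of hydrogen on a saturated chain carbon bound to an aromatic nitrogen), with hydroxymethyl in place of hydrogen on a saturated chain carbon bound to an aromatic nitrogen. Put another way, methyl becomes 2-hydroxyethyl.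

Within the data shown here, the only measured step between compounds differing in one place is a 4.0-fold lower number from compound 2 to compound 3 (0.60 log units; beyond the scatter), and it concerns pyridin-3-yl in place of phenyl on an amide-type nitrogen. It is a different change at a different place, so it bears on this one only indirectly. Compound 2 and compound 3 each differ from compound 1 in more than one place, so the gap in their numbers cannot be assigned to the group on the aromatic nitrogen alone. No measurement tests this change directly, so no step beyond the scatter is expected in this assay in either direction, though the uncertainty is wide. The estimated change is a 1.1-fold lower number from compound 1 to compound 4 (0.05 log units; within the scatter) as an expected figure. Compound 4 is estimated at 150 nM with an expected range from 50 nM to 450 nM in this read-out.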

Compound 4, half-maximal inhibitory concentration: 650 nM
Beside the measured number, compound 4's estimate is 4.3-fold (0.64 log units) below it, outside the stated range (above it).
By their numbers in this assay, from the lowest: compound 3; then compound 2; then compound 1; then compound 4.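

In this assay, among these compounds, the change gives a 3.8-fold higher number from compound 1 to compound 4 (0.58 log units; beyond the scatter) and so provides the first direct reading at this position, with the rest of the structure held fixed. It shows that the group on the aromatic nitrogen is not indifferent here: hydroxymethyl in place of hydrogen on a saturated chain carbon bound to an aromatic nitrogen, which is the same difference as methyl to 2-hydroxyethyl, moves the number towards weaker inhibition by a modest step beyond the scatter. No measured evidence bears on this step, so the data at hand offer no explanation for it.

Among the compounds shown here, with only this one step, the added carbon and the added hydroxyl cannot be told apart, and an ethyl group on the same nitrogen, which has the two-carbon chain without the hydroxyl, would be the natural group to separate them. Also open, as far as these compounds go, is how other chains at this place would read, such as a 2-methoxyethyl group, an amine or a carboxylic acid at the chain end, or a longer chain, and whether the step would hold alongside the phenyl of compound 2 or the pyridin-3-yl of compound 3.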